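This account rests on a few compounds, and the source may have more. Where it says the series, first, only, none or still open, it means among the compounds named here.

In an ADME assay on MT4 cells (Homo sapiens) for cytotoxicity, read by MTT assay (on this read-out lower numbers stand for higher toxicity in this test and higher numbers for lower toxicity in this test), compound 1 `O=C1c2ccccc2C(=O)N1CCOC(=S)N(C(=O)c1ccc(F)c(F)c1)c1ccc(Cl)cc1` gives 52000 nM and compound 2 `O=C1c2ccccc2C(=O)N1CCOC(=S)N(C(=O)c1cccc(Cl)c1Cl)c1ccc(Cl)cc1` gives 54000 nM while compound 3 `COc1cccc(OC)c1C(=O)N(C(=S)OCCN1C(=O)c2ccccc2C1=O)c1ccc(Cl)cc1` gives 69000 nM so compound 3 stands level with the other two, within the scatter of both. Compound 4 `O=C1c2ccccc2C(=O)N1CCOC(=S)N(C(=O)c1ccc(Cl)c([N+](=O)[O-])c1)c1ccc(Cl)cc1` brings one change to compound 3: 4-chloro-3-nitrophenyl in place of 2,6-dimethoxyphenyl on a carbonyl carbon with 4-chloro-3-nitrophenyl in place of 2,6-dimethoxyphenyl on a carbonyl carbon. Three measured swaps at that same place bear on it: a 1.0-fold higher number from compound 1 to compound 2 (0.02 log units; within the scatter) and a 1.3-fold higher number from compound 1 to compound 3 (0.12 log units; within the scatter) and a 1.3-fold higher number from compound 2 to compound 3 (0.11 log units; within the scatter) all stay within the scatter. None of these compounds carries the incoming group, so this is a loose forecast, but no step beyond the scatter is expected in this assay here. The expected step is a 1.4-fold lower number from compound 3 to compound 4 (0.14 log units; within the scatter) in size. For compound 4 the estimate is 50000 nM with an expected range of 22000 nM to 90000 nM for the coming measurement.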

Compound 4, half-maximal cytotoxic concentration: 48000 nM
The estimate for compound 4 lay 1.0-fold (0.02 log units) above the measured number; measured number inside the range.
By their numbers in this assay, from the lowest: compounds 4, 1, 2 and 3 (each within the scatter of the next).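

In this assay, the 4-chloro-3-nitrophenyl group on a carbonyl carbon puts compound 4 level with all three earlier compounds: a 1.4-fold lower number from compound 3 to compound 4 (0.16 log units; within the scatter), a 1.1-fold lower number from compound 2 to compound 4 (0.05 log units; within the scatter) and a 1.1-fold lower number from compound 1 to compound 4 (0.03 log units; within the scatter). A nitro-bearing phenyl ring therefore joins the fluoro, chloro and methoxy versions, and all four phenyl groups at this place give numbers within the scatter of one another. Nothing measured here accounts for this evenness.

Going by these compounds, whether an amine, a carboxylic acid or a longer chain in place of the phenyl ring would give a step beyond the scatter stays open. On these data alone, the rest of the molecule is the same in all four compounds, so the effect of a change elsewhere is also open.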